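Pyridin-4-yl to 3-carbamoylphenyl: working notes on the series

The source may hold more compounds than are shown below. What is called first, only, known or untested is meant among the compounds shown, and "the series" means these compounds.

Compound 1 `CN1CCC(CNC(=O)c2cccc(-c3ccc(F)c(C(=O)Nc4c[nH]nc4C(=O)Nc4ccc(F)cc4)c3F)c2)CC1`: 3340 nM
Compound 2 `O=C(Nc1ccc(F)cc1)c1n[nH]cc1NC(=O)c1c(F)ccc(-c2ccncc2)c1F`: 2940 nM

Both values come from a functional assay on A2058 cells (Homo sapiens) for antiproliferative activity, read by luminescence and CellTiter-Glo, with a stated time of 96 h; on this read-out lower numbers stand for stronger inhibition and higher numbers for weaker inhibition. Compound 2, at 2940 nM, lies within the scatter of compound 1, so neither stands apart on these numbers.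

Compound 3 `NC(=O)c1cccc(-c2ccc(F)c(C(=O)Nc3c[nH]nc3C(=O)Nc3ccc(F)cc3)c2F)c1` has 3-carbamoylphenyl in place of the pyridin-4-yl of compound 2, on an aromatic carbon ortho to a fluoro group and para to a fluoro group (3-carbamoylphenyl in place of pyridin-4-yl on an aromatic carbon).

Among the compounds with values here, no measured pair yet isolates a single change, so the data give no direct guide to this one. With compound 1 at 3340 nM and compound 2 at 2940 nM, no step beyond the scatter is expected in this assay. The expected change is a 1.0-fold higher number from compound 2 to compound 3 (0.01 log units; within the scatter). The estimated value for compound 3 is 3000 nM, with an expected range of 1000 nM to 9000 nM.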

Compound 3, half-maximal inhibitory concentration: 1990 nM
Beside the measured number, compound 3's estimate is 1.5-fold (0.18 log units) above it; low and high end bracket the measured number.
By their numbers in this assay, from the lowest: compounds 3, 2 and 1 (each within the scatter of the next).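

At this aromatic carbon, ortho to a fluoro group and para to a fluoro group, 3-carbamoylphenyl in place of pyridin-4-yl gives a 1.5-fold lower number from compound 2 to compound 3 (0.17 log units; within the scatter) in this assay, so a ring of carbon only bearing the carbamoyl group can stand here without a step beyond the scatter. Hydrogen in place of (1-methylpiperidin-4-yl)methyl on the amide-type nitrogen gives a 1.7-fold lower number from compound 1 to compound 3 (0.22 log units; within the scatter), so this side chain also brings no step beyond the scatter. No measurement in hand accounts for either step.

The compounds shown include no change at this position that moves the number beyond the scatter. From the compounds shown here alone, whether a carboxylic acid in place of the carbamoyl group, or a short primary amine chain on the amide-type nitrogen, would do so remains open.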